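A few compounds are considered here, and "the series" means these few. Any claim that something is new, unique, unknown or untested is made for them only; others in the source may bear on it.

- Compound 1 `O=C1[C@H]2N=NN(Cc3nc(-c4ccc(Br)cc4)no3)[C@H]2C(=O)N1c1ccccc1` gives 58.6 ug/mL
- Compound 2 `O=C1[C@H]2N=NN(Cc3nc(-c4ccc(Cl)cc4)no3)[C@H]2C(=O)N1c1ccccc1` gives 49.5 ug/mL

Both values come from an ADME assay on L6 cells (Rattus norvegicus) for cytotoxicity, read by resazurin assay, with a stated time of 72 h; on this read-out higher numbers stand for weaker inhibition and lower numbers for stronger inhibition. Of the two numbers available, compound 2 stands within the scatter of compound 1.

The next compound is compound 3 `O=C1[C@H]2N=NN(Cc3nc(-c4ccc(F)cc4)no3)[C@H]2C(=O)N1c1ccccc1`, which has fluoro in place of chloro on an aromatic carbon, para to a large group (fluoro in place of chloro on an aromatic carbon). The same difference reads as 4-chlorophenyl to 4-fluorophenyl.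

Within the data shown here, only one measured step bears on this change, the exchange of one halogen for another at the same place. That step is a 1.2-fold lower number from compound 1 to compound 2 (0.07 log units; within the scatter). Among the measured compounds shown here, no measured compound carries fluoro, so this step is indirect evidence and the range stays wide. On this single step, no change beyond the scatter is expected in this assay, and no direction is favoured. The expected step is a 1.1-fold higher number from compound 2 to compound 3 (0.05 log units; within the scatter). The estimated value for compound 3 is 55 ug/mL, with an expected range from 28 ug/mL to 105 ug/mL.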

Compound 3, half-maximal inhibitory concentration: > 100 ug/mL
Compound 3: a limit, no number; the forecaster's own chance of this, stated with the estimate: 10%; middle value at least 1.8-fold (0.25 log units) from the limit.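

In this assay the reading for compound 3 is a limit and not a number: the limit of > 100 ug/mL in this assay, at which 1 of the 3 values shown sits. Going from 4-chlorophenyl to 4-fluorophenyl gives an at least 2.0-fold higher number from compound 2 to compound 3 (0.30 log units; that floor lies within the scatter), and fluoro in place of bromo on the same aromatic carbon gives an at least 1.7-fold higher number from compound 1 to compound 3 (0.23 log units; that floor lies within the scatter); both floors lie within the scatter, so the limit does not yet separate fluoro from the other two halogens, though the true gaps may be larger. Among these compounds, the exchange of bromo for chloro gave a 1.2-fold lower number from compound 1 to compound 2 (0.07 log units; within the scatter), a flat step with both readings on scale, whereas the fluoro member is the first in this set with an open upper end, so this position can no longer be described as flat across all three halogens.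

Going by these compounds, how far compound 3 lies beyond its limit remains open, and with it whether fluoro differs from chloro and bromo by more than the scatter. Also open, on these data alone, is whether a methoxy group, an amine or a carboxylic acid at this place on the phenyl ring would give a reading on scale, and on which side of the halogens it would fall.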